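Moving the fluorine on compound 2

The source may report more compounds than this note shows. Statements on the series, on what has been measured and on what is new or still open speak of the compounds shown alone.

In a functional assay on MCF7 cells (Homo sapiens) for inhibition, read by MTT assay, with a stated time of 72 h (on this read-out higher numbers stand for weaker inhibition and lower numbers for stronger inhibition), compound 1 `Nc1ccccc1NC(=O)c1ccc(CNC(=O)/C=C/c2c[nH]c3ccccc23)cc1` gives 2920 nM, compound 3 `Cc1nc2ccccn2c1/C=C/C(=O)NCc1ccc(C(=O)Nc2ccccc2N)cc1` gives 6220 nM and compound 2 `Nc1ccc(F)cc1NC(=O)c1ccc(CNC(=O)/C=C/c2cnc3cccnn23)cc1` gives 11000 nM. The numbers for compound 2 and compound 3 lie within the scatter of each other, and both stand higher than the number for compound 1.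

Compound 4 `Nc1cc(F)ccc1NC(=O)c1ccc(CNC(=O)/C=C/c2cnc3cccnn23)cc1` carries 2-amino-4-fluorophenyl in place of 2-amino-5-fluorophenyl on an amide-type nitrogen. Going by the values given here, the only measured single change, a 2.1-fold higher number from compound 1 to compound 3 (0.33 log units; beyond the scatter), is modest and lies elsewhere in the structure, so it offers little guidance here. No step beyond the scatter is therefore expected in this assay, in either direction. The estimated change is a 1.1-fold lower number from compound 2 to compound 4 (0.04 log units; within the scatter). For compound 4 the expected value is 10000 nM, with an estimated range of 4500 nM to 22000 nM.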

Compound 4, half-maximal inhibitory concentration: 5510 nM
Beside the measured number, compound 4's estimate is 1.8-fold (0.26 log units) above it; low and high end bracket the measured number.
By their numbers in this assay, from the lowest: compounds 1, 4, 3 and 2 (each within the scatter of the next, the first and the last beyond it).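

In this assay, going by these compounds alone, the step of a 2.0-fold lower number from compound 2 to compound 4 (0.30 log units; within the scatter) comes with 2-amino-4-fluorophenyl in place of 2-amino-5-fluorophenyl on an amide-type nitrogen, the first reading at this place. Moving the fluorine between these two sites on the ring therefore does not separate compound 2 and compound 4 beyond the usual scatter, whereas the earlier single change lay elsewhere in the structure. No available evidence bears on this result.

Still open, going by these compounds, is how a chlorine or methoxy group in place of the fluorine would read on this core. Also open is whether either fluorine contributes at all, since no unfluorinated 2-aminophenyl counterpart with this core is shown.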